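The source may report more compounds than this note shows. Statements on the series, on what has been measured and on what is new or still open speak of the compounds shown alone.

Measured compounds:
compound 1 `C[C@H](NC(=O)Nc1ccc(C(C)(C)C)cc1)c1ccccc1`: 88%
compound 2 `CCCCc1ccc(NC(=O)N[C@@H](C)c2ccccc2)cc1`: 72%
compound 3 `CCOC(=O)c1ccc(NC(=O)N[C@@H](C)c2ccccc2)cc1`: 97%

In an ADME assay on the whole organism with Oryza sativa as the target, tested at 1 uM (a lower number here means a stronger effect, a higher number a weaker effect of the compound at the concentration tested), compound 3 holds the highest of the three numbers; compound 1 lies within the scatter of it, whereas the step of a number 25 percentage points higher from compound 2 to compound 3 (beyond the scatter) lies beyond the scatter. Compound 4 `C[C@H](NC(=O)Nc1ccc(F)cc1)c1ccccc1` differs from compound 3 by fluoro in place of ethoxycarbonyl on an aromatic carbon. The steps of a number 9 percentage points higher from compound 1 to compound 3 (within the scatter) and a number 25 percentage points higher from compound 2 to compound 3 (beyond the scatter) both concern the ethoxycarbonyl group that leaves, but neither of them, nor any other measured step, introduces fluoro, so their bearing is indirect. For compound 4 a modest downward step is expected, a number 15 percentage points lower from compound 3 to compound 4 (beyond the scatter), with wide uncertainty. Compound 4 is estimated at 82%, within a range from 65% to 97%.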

Compound 4, a percentage reported as activity, at one concentration (the size of the read-out at that concentration, not a potency): 97%
Compound 4: middle estimate off by 15 percentage points, on the low side; measured number inside the range.
By their numbers in this assay, from the lowest: compound 2; then compounds 1, 3 and 4 (each within the scatter of the next).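

The fluoro group, much smaller than the ethoxycarbonyl group it replaces, gives no change at the digits printed from compound 3 to compound 4 (within the scatter) at this position (this assay), and the change from tert-butyl gives a number 9 percentage points higher from compound 1 to compound 4 (within the scatter). The change from butyl gives a number 25 percentage points higher from compound 2 to compound 4 (beyond the scatter), so among the four groups at this position only butyl stands apart, and nothing at hand explains this.

Going by these compounds, whether a longer chain than butyl would lower the number further remains open. So does whether an amine or a carboxylic acid at this position would stay with fluoro, tert-butyl and ethoxycarbonyl.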